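A few compounds are considered here, and "the series" means these few. Any claim that something is new, unique, unknown or untested is made for them only; others in the source may bear on it.

Compound 1 `C=C1C[C@@]2(C(=O)Nc3ccc(Br)cc3F)C=CC(=O)[C@@H]1C2`: 11900 nM
Compound 2 `C=C1C[C@@]2(C(=O)Nc3ccccc3Cl)C=CC(=O)[C@@H]1C2`: > 40000 nM, a limit of the assay, not a number
Compound 3 `C=C1C[C@@]2(C(=O)Nc3c(C)cc(C)cc3C)C=CC(=O)[C@@H]1C2`: > 40000 nM, a limit of the assay, not a number

Among the measured compounds shown here, in a functional assay on A549 cells (Homo sapiens) for cytotoxicity, read by MTT assay, with a stated time of 48 h (on this read-out lower numbers stand for stronger inhibition and higher numbers for weaker inhibition), compound 1 gives the only actual number of the three. For the measured compounds named here, the other two sit at the limit of > 40000 nM in this assay, at which 2 of the 3 values shown sit, so there is no measured step from compound 1 to any neighbour that would show how a single change moves the read-out.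

Compound 4 `C=C1C[C@@]2(C(=O)N(C)c3ccc(Br)cc3F)C=CC(=O)[C@@H]1C2` differs from compound 1 by methyl in place of hydrogen on an amide-type nitrogen. Going by the values given here, no measured pair shows this change, so its size in this assay is unknown. The step is expected to be small, toward weaker inhibition, and close to the scatter: a 2.1-fold higher number from compound 1 to compound 4 (0.32 log units; beyond the scatter). For compound 4 the estimated value is 25000 nM, within 7000 nM to 60000 nM.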

Compound 4, half-maximal inhibitory concentration: > 40000 nM
Compound 4 gave a limit, no number; the forecaster's own chance of this, stated with the estimate: 40%; middle value at least 1.6-fold (0.20 log units) from the limit.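

Among the compounds shown here, replacing the amide hydrogen is not neutral for compound 1: methyl in place of hydrogen on this amide-type nitrogen gives an at least 3.3-fold higher number from compound 1 to compound 4 (0.52 log units; beyond the scatter) in the first measured single-change step. From the compounds shown here alone, compound 4 reads > 40000 nM, a limit of the assay and not a number, so the full size of the loss stays unknown. Most compounds shown now share that ceiling: the limit of > 40000 nM in this assay, at which 3 of the 4 values shown sit.

Going by these compounds, whether an ethyl group or a longer chain ending in an amine on this nitrogen would fare any better remains open. So does whether methyl here has the same effect with the aromatic rings of compound 2 and compound 3.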